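Replacing the Urea of Compound 3 with an Oxadiazole

The compounds below may be only part of what the source reports. "The series", "measured", "known", "first", "only" and "open" are said of these compounds alone.

Of the compounds shown here, three have been measured in an assay on microsomes from liver (strain Wistar) for inhibition of acyl-CoA desaturase 1 (Rattus norvegicus), read by HPLC, with stated times of 1 h and 60 min; a lower number here means a stronger inhibitor, a higher number a weaker inhibitor. Compound 1 `NC(=O)c1cnc(N2CCC(Sc3ccccc3C(F)(F)F)CC2)s1` gives 4 nM. Compound 2 `NC(=O)c1n[nH]c(N2CCC(Oc3ccccc3C(F)(F)F)CC2)n1` gives 127 nM. Compound 3 `NC(=O)Nc1cnc(N2CCC(Oc3ccccc3C(F)(F)F)CC2)s1` gives 150 nM, the highest number of the three; its gap to compound 2 lies within the scatter, while compound 1 stands well beyond it with a far lower number.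

Compound 4 `FC(F)(F)c1ccccc1OC1CCN(c2ncc(-c3ncon3)s2)CC1` is compound 3 with one change: 1,2,4-oxadiazol-3-yl in place of ureido on an aromatic carbon. For the measured compounds named here, no measured pair shows this exact step, so its size is uncertain. Still, compound 1 shows that a small group with a carbonyl at this place on the five-membered aromatic ring with 1 nitrogen and 1 sulfur can go with a low number, and the oxadiazole is another compact group at the same place. The expectation is therefore a modest gain, the step from compound 3 to compound 4 being estimated as a 2.5-fold lower number from compound 3 to compound 4 (0.40 log units; beyond the scatter). Compound 4 is expected to give about 60 nM in this assay, with a likely range from 12 nM to 300 nM.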

Compound 4, half-maximal inhibitory concentration: 4 nM
For compound 4 the middle estimate is 15-fold (1.18 log units) above the measured one, outside the stated range (below it).
By their numbers in this assay, from the lowest: compounds 1 and 4 (each within the scatter of the next); then compounds 2 and 3 (each within the scatter of the next).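

In this assay, replacing ureido with 1,2,4-oxadiazol-3-yl gives a 38-fold lower number from compound 3 to compound 4 (1.57 log units; beyond the scatter) and so shows that this place on the ring responds strongly to the group it carries. A low number here does not need the hydrogen-bond donors of ureido, since the entering group has none and brings a five-membered aromatic ring and more hydrogen-bond acceptors. Nothing shown here explains why the step is so large.

Several things change together in this one step, so the compounds shown cannot tell whether the gain comes from losing the donors, gaining the acceptors or adding the ring. A nitrile, a methyl ester or a 1,3,4-oxadiazol-2-yl group at the same place would help to separate these possibilities.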